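The source may hold more compounds than are shown below. What is called first, only, known or untested is meant among the compounds shown, and "the series" means these compounds.

Compound 2 `CN(C)c1ccc2c(=O)c(C(=O)Nc3cc(F)cc(F)c3)cn(-c3ccc(OCCCCCCC[N+]45CCN(CC4)CC5)c(Cl)c3)c2n1` gives 20.5% in an assay on LX2 cells for inhibition of COL1A1 promoter (Homo sapiens), read by a luciferase reporter, with a stated time of 24 h, tested at 50 uM; on this read-out higher numbers stand for a stronger effect at the one concentration tested and lower numbers for a weaker effect. Compound 1 `Cc1cc(-n2cc(C(=O)Nc3cc(F)cc(F)c3)c(=O)c3ccc(N(C)C)nc32)ccc1OCCCCCCC[N+]12CCN(CC1)CC2` gives 20.8% in this assay, and the step of a number 0.3 percentage points lower from compound 1 to compound 2 (within the scatter), a chloro in place of a methyl on an aromatic carbon, lies within the scatter, so the two numbers cannot be told apart. Compound 2 thus holds the lower of the two numbers only nominally. A third compound, compound 3 `CN(C)c1ccc2c(=O)c(C(=O)Nc3cc(F)cc(F)c3)cn(-c3ccc(OCCCCCCC[N+]4(C)CCCCC4)cc3F)c2n1`, is reported in this assay as "not active" (no number reported), without a number.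

Compound 4 `CC[N+]1(CCCCCCCOc2ccc(-n3cc(C(=O)Nc4cc(F)cc(F)c4)c(=O)c4ccc(N(C)C)nc43)cc2Cl)CCCCC1` keeps the chloro of compound 2 and alters the far end of the chain: a group of 8 heavy atoms (7 carbon, 1 nitrogen; one six-membered non-aromatic ring with 1 hetero atom) in place of a group of 8 heavy atoms (6 carbon, 2 nitrogen; 2 six-membered non-aromatic rings with 2 hetero atoms each), on a saturated chain carbon, seven bonds along the chain from an oxygen on an aromatic ring. Going by the values given here, no measured step touches this position. Among the compounds with values here, the only step in hand, a number 0.3 percentage points lower from compound 1 to compound 2 (within the scatter), concerns an aromatic substituent and was within the scatter, so it says nothing about the chain end. Within the data shown here, compound 3 differs from compound 2 in more than one place, so no single step can be drawn from it; its report of no activity is the only hint that changes away from compound 2 can cost effect. On this thin basis, a fall in this assay is expected for compound 4, of the size a number 11.5 percentage points lower from compound 2 to compound 4 (beyond the scatter). Compound 4 is therefore estimated at 9%, with a range of 0% to 22%, and a fair chance that it is reported only as not active.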

Compound 4, a percentage reported as inhibition, at one concentration (the size of the read-out at that concentration, not a potency): 50.4%
Compound 4: the middle estimate sits 41.4 percentage points below what was measured; the measured number lies above the stated range.
By their numbers in this assay, from the lowest: compounds 2 and 1 (each within the scatter of the next); then compound 4.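

Going by these compounds alone, the far end of the chain is the first place where a change moves the read-out in this assay: the swap gives a number 29.9 percentage points higher from compound 2 to compound 4 (beyond the scatter), whereas the earlier aromatic exchange of chloro for methyl gave only a number 0.3 percentage points lower from compound 1 to compound 2 (within the scatter). Net charge stays at +1 across the swap, so the step arises between two groups of 8 heavy atoms that match in size and charge, with the one with 2 six-membered non-aromatic rings leaving and the one with one such ring entering, along with the loss of the 1 hydrogen-bond acceptor counted on the departing group. Nothing measured here explains why the number rises, and no single feature of the swap can be singled out.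

Going by these compounds, it remains open whether the same chain end would give a similar rise with the methyl of compound 1 on the aromatic carbon in place of the chloro. Also open, on these data alone, is how a morpholine ring at the chain end, or a longer or shorter chain carrying the ring of compound 4, would read in this assay.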